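From thiophen-3-yl to 3-methoxyphenyl: working notes

This account rests on a few compounds, and the source may have more. Where it says the series, first, only, none or still open, it means among the compounds named here.

Compound 1 `COc1cc(C(=O)c2sc(-c3ccc(Br)cc3)cc2N)cc(OC)c1OC` gives 86 nM in a functional assay on CCRF-CEM cells (Homo sapiens) for antiproliferative activity; a higher number here means a weaker inhibitor, a lower number a stronger inhibitor
Compound 2 `COc1ccc(-c2cc(N)c(C(=O)c3cc(OC)c(OC)c(OC)c3)s2)cc1OC` gives 20 nM
Compound 3 `COc1cc(C(=O)c2sc(-c3ccsc3)cc2N)cc(OC)c1OC` gives 9.6 nM

Compound 3 has the lowest of the three numbers in this assay with compound 2 nearest and compound 1 furthest. Compound 4 `COc1cccc(-c2cc(N)c(C(=O)c3cc(OC)c(OC)c(OC)c3)s2)c1` is unmeasured and differs from compound 3 at one place 3-methoxyphenyl in place of thiophen-3-yl on an aromatic carbon which amounts to 3-methoxyphenyl in place of thiophen-3-yl on an aromatic carbon.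

Two measured steps at this place bear on the change. Both a 2.1-fold lower number from compound 2 to compound 3 (0.32 log units; beyond the scatter) and a 9.0-fold lower number from compound 1 to compound 3 (0.95 log units; beyond the scatter) replace a substituted phenyl with thiophen-3-yl and run toward a lower number, and neither compound goes against this. The closer precedent is compound 2 with its 3,4-dimethoxyphenyl group, so the reverse direction and a modest size are expected here. The estimated step is a 2.9-fold higher number from compound 3 to compound 4 (0.46 log units; beyond the scatter) in this assay and its size remains an expectation. In this assay the estimated value for compound 4 is 28 nM (expected range 10 nM to 90 nM).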

Compound 4, half-maximal inhibitory concentration: 16 nM
Compound 4: the middle estimate sits 1.8-fold (0.24 log units) above what was measured; the range from low to high includes it.
By their numbers in this assay, from the lowest: compounds 3, 4 and 2 (each within the scatter of the next, the first and the last beyond it); then compound 1.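

In this assay, a 1.7-fold higher number from compound 3 to compound 4 (0.22 log units; within the scatter), so at this carbon next to the ring sulfur a six-membered aromatic ring of carbon only can stand within the scatter of thiophen-3-yl, which the two earlier substituted phenyl groups did not do. The step of a 1.3-fold lower number from compound 2 to compound 4 (0.10 log units; within the scatter) shows that hydrogen in place of methoxy on the phenyl group gives no difference beyond the scatter, so the 3,4-dimethoxyphenyl and 3-methoxyphenyl groups cannot be told apart here. With a 5.4-fold lower number from compound 1 to compound 4 (0.73 log units; beyond the scatter), compound 1 remains separated beyond the scatter from compounds 2, 3 and 4, and the 4-bromophenyl group is the only one of the four that stands apart.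

Nothing shown gives a reason for these differences. From the compounds shown here alone, whether an aminomethyl or carboxylic acid group on the phenyl ring, or a saturated piperidine ring at this carbon, would stay within this range remains open.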